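Chlorine position on the benzyl group across two cores

A few compounds are considered here, and "the series" means these few. Any claim that something is new, unique, unknown or untested is made for them only; others in the source may bear on it.

Compound 1 `COc1ccc(C2N=C(SCc3cccc(Cl)c3)NC(C)=C2C(=O)Nc2ccc(F)cc2)cc1OC` and compound 2 `COc1ccc(C2N=C(SCc3ccc(Cl)cc3)NC(C)=C2C(=O)Nc2ccc(F)cc2)cc1OC` share one core. In a functional assay on the whole organism (artery, strain albino) with Rattus norvegicus as the target, with a stated time of 240 min, at a dose of 10 mg/kg by the oral route (a higher number here means more inhibition at the dose given (going by the name of the read-out), a lower number less inhibition), compound 1 gives 14.9% and compound 2 gives 24.1%. The change between them is 4-chlorophenyl in place of 3-chlorophenyl on a saturated chain carbon bound to a sulfur, and it made a step of a number 9.2 percentage points higher from compound 1 to compound 2 (within the scatter). Compound 3 `CC1=C(C(=O)Nc2ccc(Br)cc2)C(c2ccc(Cl)cc2Cl)N=C(SCc2cccc(Cl)c2)N1` is built on a second core; the difference between the two cores is not broken down here. In this assay compound 3 gives 15.9%, within the scatter of both compound 1 and compound 2. Compound 4 `CC1=C(C(=O)Nc2ccc(Br)cc2)C(c2ccc(Cl)cc2Cl)N=C(SCc2ccc(Cl)cc2)N1` is not yet measured; it differs from compound 3 by 4-chlorophenyl in place of 3-chlorophenyl on a saturated chain carbon bound to a sulfur, the same change at the same place as the one seen before. In this assay, for the measured compounds named here, the expected step is a number 7.1 percentage points higher from compound 3 to compound 4 (within the scatter), resting on the one earlier step of this change, a number 9.2 percentage points higher from compound 1 to compound 2 (within the scatter), which stayed within the scatter. Compound 4 is accordingly estimated at 23% in this assay, with a range from 10% to 36%.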

Compound 4, a percentage reported as inhibition, in the whole organism at one dose (the size of the read-out at that dose, not a potency): 32.3%
For compound 4 the middle estimate is 9.3 percentage points below the measured one; low and high end bracket the measured number.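

In this assay, 4-chlorophenyl in place of 3-chlorophenyl on a saturated chain carbon bound to a sulfur gives a number 16.4 percentage points higher from compound 3 to compound 4 (beyond the scatter). The change points the same way on both cores, and the gap in size stays within what two such steps can scatter: the same change on two cores in this assay, a number 9.2 percentage points higher (within the scatter) from compound 1 to compound 2 and a number 16.4 percentage points higher (beyond the scatter) from compound 3 to compound 4, 7.2 percentage points apart, within the scatter of two such steps. For the compounds shown here, this supports carrying the direction of the change from one of these two cores to the other, but with only one of the two steps beyond the scatter, it fixes no size of step and sets no rule for any further core.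

Still open, as far as these compounds go, is whether the step holds with a nitrile or a carboxylic acid in place of the chlorine on the benzyl group. From the compounds shown here alone, a longer chain in place of the benzyl group is equally open.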